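The compounds below may be only part of what the source reports. "The series", "measured", "known", "first", "only" and "open" are said of these compounds alone.

Of the compounds shown here, three have been measured in an assay for inhibition of RAC-alpha serine/threonine-protein kinase (Homo sapiens), read by HTRF, with a stated time of 1 h; on this read-out lower numbers stand for stronger inhibition and higher numbers for weaker inhibition. Compound 1, `Cn1ncc(Cl)c1-c1cc(C(=O)N[C@@H]2CN[C@H](CCn3cncn3)C[C@H]2c2ccc(Cl)c(Cl)c2)oc1Cl`, gives 4.47 nM in this assay. Compound 2, `Cn1ncc(Cl)c1-c1cc(C(=O)N[C@@H]2CNCC[C@H]2c2ccc(C(F)(F)F)cc2)oc1Cl`, gives 9.3 nM. Compound 3, `CNC(=O)C[C@@H]1C[C@@H](c2ccc(F)c(F)c2)[C@H](NC(=O)c2cc(-c3c(Cl)cnn3C)c(Cl)o2)CN1`, gives 1.37 nM. Among these three numbers compound 1 holds the second highest; compound 2 sits closest to it with a higher number, and compound 3 lies furthest away with a lower one, both gaps being beyond the usual scatter of repeated runs.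

Compound 4, `Cn1ncc(Cl)c1-c1cc(C(=O)N[C@@H]2CN[C@H](CC(N)=O)C[C@H]2c2ccc(Cl)c(Cl)c2)oc1Cl`, has not yet been measured. It differs from compound 1 in one place: carbamoyl in place of (1H-1,2,4-triazol-1-yl)methyl on a saturated chain carbon bound to a saturated ring carbon. A six-atom aromatic-ring group with three acceptors leaves, and a three-atom group with one donor and one acceptor enters on the same chain carbon.

Among the compounds with values here, no measured pair shows this exact exchange, so the direction rests on the surrounding numbers only. Compound 3, which carries a different chain at the same region of the shared core, gives 1.37 nM, the lowest of the three. The step of a 1.3-fold lower number from compound 1 to compound 4 (0.11 log units; within the scatter) is therefore expected to be small and toward a lower number, possibly not beyond the scatter. Compound 4 is estimated to give 3.5 nM, within a range from 1.2 nM to 10 nM.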

Compound 4, half-maximal inhibitory concentration: 3.24 nM
Beside the measured number, compound 4's estimate is 1.1-fold (0.03 log units) above it, and the stated range covers the measured number.
By their numbers in this assay, from the lowest: compound 3; then compounds 4 and 1 (each within the scatter of the next); then compound 2.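

In this assay, within the data shown here, putting carbamoyl in place of (1H-1,2,4-triazol-1-yl)methyl on a saturated chain carbon bound to a saturated ring carbon gives a 1.4-fold lower number from compound 1 to compound 4 (0.14 log units; within the scatter), the first direct reading of a single change in this set. At this position, a group with a five-membered aromatic ring and 6 heavy atoms and a group with no ring and 3 heavy atoms therefore cannot be told apart by this read-out, even though one has 0 hydrogen-bond donors and the other has 1. Nothing measured here accounts for this similarity.

The compounds shown leave open how a primary amine, a carboxylic acid or a longer chain ending in carbamoyl would read on the same chain carbon, so the limits of what this position accepts remain unknown. Compound 2 and compound 3 each differ from compound 4 in more than one place, so they cannot show what the chain contributes on its own.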